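The compounds below may be only part of what the source reports. "The series", "measured", "known", "first", "only" and "open" are said of these compounds alone.

In a functional assay (Cardiac muscle cell, Rattus norvegicus, strain Sprague-Dawley) for inhibition, read by LDH release, with a stated time of 6 h (on this read-out lower numbers stand for an effect already at smaller amounts and higher numbers for an effect only at larger amounts of compound), compound 1 `COC(=O)c1oc2ccccc2c1NC(=O)CSc1ccc(Br)cc1` gives 778 nM and compound 2 `COC(=O)c1oc2cccc(Cl)c2c1NC(=O)CSc1ccc(Br)cc1` gives 630 nM. Within the data shown here, these are the only two numbers known so far, and they lie within the usual scatter of each other, so compound 1 has no clear rank. Compound 3 `COC(=O)c1oc2ccccc2c1NC(=O)CCSc1ccccn1` keeps the core of compound 1 but alters its side chain: ((pyridin-2-yl)sulfanyl)methyl in place of (4-bromophenyl)sulfanyl on a saturated chain carbon bound to a carbonyl carbon. Among the measured compounds shown here, the one measured step, a 1.2-fold lower number from compound 1 to compound 2 (0.09 log units; within the scatter), comes from chloro in place of hydrogen on an aromatic carbon. That is a different change, and it was small, so it offers no direction here. For the measured compounds named here, no measured step touches this side chain, which leaves the value of compound 1 as the only anchor and makes the range wide. The expected step in this assay is a 1.2-fold higher number from compound 1 to compound 3 (0.06 log units; within the scatter), so no shift beyond the scatter is expected. Compound 3 is estimated at 900 nM, with a range of 250 nM to 3000 nM.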

Compound 3, half-maximal effective concentration: 929 nM
Compound 3: middle estimate off by 1.0-fold (0.01 log units), on the low side; measured number inside the range.
By their numbers in this assay, from the lowest: compounds 2, 1 and 3 (each within the scatter of the next).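

In this assay, among these compounds, the new side chain gives a 1.2-fold higher number from compound 1 to compound 3 (0.08 log units; within the scatter), the only measured step that touches this place, on a saturated chain carbon bound to a carbonyl carbon. It shows that ((pyridin-2-yl)sulfanyl)methyl can stand in place of (4-bromophenyl)sulfanyl with no shift beyond the usual scatter, even though the bromine leaves, a ring nitrogen enters and the count of hydrogen-bond acceptors changes. Nothing measured here explains why the number stays within the scatter.

From the compounds shown here alone, this single step changes the ring and the chain together, so the contribution of each remains unknown. Going by these compounds, it also remains open whether a carboxylic acid or an amine on this side chain, or a plain phenyl ring without the bromine, would move the number beyond the scatter.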